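Aryl ketone variation on the shared core

The source may hold more compounds than are shown below. What is called first, only, known or untested is meant among the compounds shown, and "the series" means these compounds.

Compound 1, `COc1cc(-c2nnc3n2NC(c2ccco2)C(C(=O)c2ccc(Cl)cc2)S3)cc(OC)c1OC`: 67800 nM in a functional assay on PC-3 cells (Homo sapiens) for cytotoxicity, read by MTT assay, with a stated time of 48 h; a lower number here means a stronger inhibitor, a higher number a weaker inhibitor
Compound 2, `COc1cc(-c2nnc3n2NC(c2ccco2)C(C(=O)c2ccc([N+](=O)[O-])cc2)S3)cc(OC)c1OC`: 27900 nM in this assay

Within the data shown here, compound 2 holds the lower of the two numbers in this assay; its only neighbour is compound 1, separated from it by a 2.4-fold lower number from compound 1 to compound 2 (0.39 log units; beyond the scatter), a modest step beyond the scatter. Compound 3, `COc1cc(-c2nnc3n2NC(c2ccco2)C(C(=O)c2cccc(Br)c2)S3)cc(OC)c1OC`, is not yet measured. It differs from compound 2 by 3-bromophenyl in place of 4-nitrophenyl on a carbonyl carbon. Among the measured compounds shown here, the one measured step that bears on this change is a 2.4-fold lower number from compound 1 to compound 2 (0.39 log units; beyond the scatter), in which a halogen on the aromatic carbon gave way to a nitro group and the number fell. Compound 3 puts a halogen back in place of the nitro, though a bromine at the 3-position rather than a chlorine at the 4-position, so the expected direction is back toward the number of compound 1, at a similar modest size. Compound 3 is therefore estimated at 60000 nM, within 25000 nM to 150000 nM, which means an expected step of a 2.2-fold higher number from compound 2 to compound 3 (0.33 log units; beyond the scatter).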

Compound 3, half-maximal inhibitory concentration: 63900 nM
Compound 3: the middle estimate sits 1.1-fold (0.03 log units) below what was measured; the range from low to high includes it.
By their numbers in this assay, from the lowest: compound 2; then compounds 3 and 1 (each within the scatter of the next).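

In this assay, the change to 3-bromophenyl on the carbonyl carbon gives a 2.3-fold higher number from compound 2 to compound 3 (0.36 log units; beyond the scatter), so 4-nitrophenyl now holds the lowest number against two different halogen-bearing aryl groups rather than one. Replacing 4-chlorophenyl with 3-bromophenyl gives a 1.1-fold lower number from compound 1 to compound 3 (0.03 log units; within the scatter), so these two groups cannot be told apart at this position, although they differ in both halogen and ring position. The data shown offer no measurement that explains the gap between 4-nitrophenyl and the two halogen-bearing groups.

Going by these compounds, whether the lower number is specific to the nitro group remains open, as a plain phenyl or an aryl ketone carrying a nitrile or an amine would be needed to judge that. The compounds shown also leave open whether changes elsewhere on the shared core would shift the number further.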